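Pyridinyl-benzimidazoles in rat paw edema: ester for hydroxymethyl

A few compounds are considered here, and "the series" means these few. Any claim that something is new, unique, unknown or untested is made for them only; others in the source may bear on it.

Measured so far in a functional assay on the whole organism with Rattus norvegicus as the target, read by paw edema, with a stated time of 3 h, at a dose of 100 mg/kg by the oral route; on this read-out lower numbers stand for less inhibition and higher numbers for more inhibition at the one dose given (going by the name of the read-out):
Compound 1 `OCc1ccc(-c2nc3ccccc3[nH]2)nc1` gives -10%.
Compound 2 `OCc1cccc(-c2nc3ccccc3[nH]2)n1` gives -13%.
Compound 3 `CCOC(=O)c1ccc(-c2nc3ccccc3[nH]2)nc1` gives -16%.

All three numbers lie within the usual scatter of one another, so no order among them can be claimed. The difference between the core of compound 1 and the core of compound 2 is not broken down here. One step is measured: ethoxycarbonyl in place of hydroxymethyl on an aromatic carbon, giving a number 6 percentage points lower from compound 1 to compound 3 (within the scatter).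

Compound 4 `CCOC(=O)c1cccc(-c2nc3ccccc3[nH]2)n1` is not yet measured. It arises from compound 2 by ethoxycarbonyl in place of hydroxymethyl on an aromatic carbon. This is the same kind of change as that from compound 1 to compound 3, but the place differs: here the group sits next to the ring nitrogen and meta to a group of 9 heavy atoms, whereas in compound 3 it sits two atoms from the ring nitrogen and para to that group.

Resting on compound 1 to compound 3 giving a number 6 percentage points lower from compound 1 to compound 3 (within the scatter), the step from compound 2 to compound 4 in this assay is expected to be a number 2 percentage points lower from compound 2 to compound 4 (within the scatter), within the scatter. Compound 4 is therefore estimated at -15%, expected between -30% and 2%.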

Compound 4, a percentage reported as inhibition, in the whole organism at one dose (the size of the read-out at that dose, not a potency): 31%
The estimate for compound 4 lay 46 percentage points below the measured number, and the stated range ends below it.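

In this assay, ethoxycarbonyl in place of hydroxymethyl on an aromatic carbon gives a number 44 percentage points higher from compound 2 to compound 4 (beyond the scatter). The step therefore does not carry from one core to the other in this series: the same change on two cores in this assay, a number 6 percentage points lower (within the scatter) from compound 1 to compound 3 and a number 44 percentage points higher (beyond the scatter) from compound 2 to compound 4, 50 percentage points apart, beyond the scatter of two such steps. These two pairs show that the outcome of this change depends on the core it is made on, but they do not show what in the core is responsible, and they give no rule for a further core.

Open, on these data alone, is whether a carboxylic acid, an amide or a longer chain in place of ethoxycarbonyl on the core of compound 4 would give a similar number. Also open, as far as these compounds go, is how the number for compound 4 behaves at other doses.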